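Cyclopropylamino for cyclohexylsulfanyl: cytotoxicity outlook

This account rests on a few compounds, and the source may have more. Where it says the series, first, only, none or still open, it means among the compounds named here.

Compound 1 `N#Cc1ccc(Nc2nccc(SC3CCCCC3)n2)cc1` is tested in an ADME assay on MT4 cells (Homo sapiens) for cytotoxicity, read by MTT assay (on this read-out lower numbers stand for higher toxicity in this test and higher numbers for lower toxicity in this test), where compound 1 gives > 402000 nM, a limit of the assay rather than a number. Compound 2 `Cc1cc(SC2CCCCC2)nc(Nc2ccc(C#N)cc2)n1` carries a methyl on the shared core; in this assay compound 2 gives >= 192000 nM, again a limit. The step that the two limits leave unreadable from compound 1 to compound 2 cannot be sized because both ends sit at limits the limit of > 402000 nM in this assay, at which 1 of the 3 values shown sits, and (the limit of >= 192000 nM in this assay, at which 1 of the 3 values shown sits). Compound 3 `Cc1cnc(Nc2ccc(C#N)cc2)nc1NC1CCCC1` has an amino-linked cyclopentyl instead of the sulfur-linked ring and a methyl on the core; in this assay compound 3 gives 170 nM. Among the compounds with values here, compound 3 differs from compound 1 in more than one place, so no single step between them is counted; the two values simply show a limit on one side and a clearly measurable toxicity on the other.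

Compound 4 `N#Cc1ccc(Nc2nccc(NC3CC3)n2)cc1` arises from compound 1 by cyclopropylamino in place of cyclohexylsulfanyl on an aromatic carbon. Within the data shown here, no measured step covers this change directly; the one counted step is unreadable. Among the measured compounds shown here, compound 3, the only amino-linked compound measured, shows that an amine at this position can go with marked toxicity, but with a different ring size and an extra methyl. Compound 4 is therefore expected to lie well above compound 3 yet possibly below the limit seen for compound 1, an estimated 100000 nM spanning 10000 nM to 400000 nM, meaning an expected step of an at least 4.0-fold lower number from compound 1 to compound 4 (0.60 log units; beyond the scatter) downward from compound 1.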

Compound 4, half-maximal cytotoxic concentration: 1190 nM
Beside the measured number, compound 4's estimate is 84-fold (1.92 log units) above it, outside the stated range (below it).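

Cyclopropylamino in place of cyclohexylsulfanyl, on the aromatic carbon next to the ring nitrogen, gives the only readable step of the series in this assay, an at least 330-fold lower number from compound 1 to compound 4 (2.52 log units; beyond the scatter). This size is a floor only, as compound 1 sits at a limit of the assay and not at a number: the limit of > 402000 nM in this assay, at which 1 of the 4 values shown sits. The position is therefore not indifferent to the group it carries in this test: with the rest of compound 1 held fixed, this one exchange moves the read-out toward higher toxicity, a point that compound 3, differing from compound 1 in more than one place, left unsettled.

The step changes the linking atom and the ring together, so the compounds shown do not separate the two, and cyclohexylamino or cyclopropylsulfanyl at this position would be the groups to tell them apart. Within the data shown here, also open is what a methyl on the shared core does when an amino-linked ring is present, and the only methyl step, taken between two sulfur-linked compounds, cannot be read.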